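A few compounds are considered here, and "the series" means these few. Any claim that something is new, unique, unknown or untested is made for them only; others in the source may bear on it.

Measured compounds in a functional assay on DU-145 cells (Homo sapiens) for inhibition, read by sulforhodamine B assay, with a stated time of 48 h; a higher number here means a weaker inhibitor of growth, a lower number a stronger inhibitor of growth:
- compound 1 `COc1ccc(-c2cc(/C=C/C(=O)c3ccc(N)cc3)[nH]n2)cc1`: 1320 nM
- compound 2 `COc1cc(-c2cc(/C=C/C(=O)c3ccc(N)cc3)[nH]n2)cc(OC)c1OC`: 1650 nM
- compound 3 `COc1ccc(C(=O)/C=C/c2cc(-c3cc(OC)c(OC)c(OC)c3)n[nH]2)cc1OC`: 550 nM

Compound 2 gives the highest of the three numbers in this assay. Compound 1 lies nearest to it, and the gap between compound 2 and compound 1 is within the scatter, so the two cannot be placed in order. Among the measured compounds shown here, compound 3 lies furthest away; the one single-point step among the measured compounds is a 3.0-fold lower number from compound 2 to compound 3 (0.48 log units; beyond the scatter), a modest change at the carbonyl end of the shared core.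

Compound 4 `COc1ccc(-c2cc(/C=C/C(=O)c3ccc(N)cc3)[nH]n2)cc1OC` is the next compound for this assay. It differs from compound 2 by hydrogen in place of methoxy on an aromatic carbon, a trimming of the aryl ring on the other end of the shared core, not the carbonyl end. The measured step from compound 2 to compound 3 concerns the carbonyl end and so does not bear on this change. What does bear on it is the pair compound 1 and compound 2: they differ in the number of methoxy groups on that same ring, and their values sit within the scatter of each other. Removing one methoxy from compound 2 is therefore expected to give a step of no more than the scatter in this assay, in no clear direction, estimated as a 1.1-fold lower number from compound 2 to compound 4 (0.06 log units; within the scatter). Compound 4 is accordingly expected at about 1450 nM, with a range from 700 nM to 3000 nM.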

Compound 4, concentration for 50% growth inhibition: 3740 nM
Beside the measured number, compound 4's estimate is 2.6-fold (0.41 log units) below it; the whole stated range lies below it.
By their numbers in this assay, from the lowest: compound 3; then compounds 1 and 2 (each within the scatter of the next); then compound 4.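

In this assay this aromatic carbon, ortho to a methoxy group, proves sensitive to the change: hydrogen in place of methoxy gives a step beyond the scatter (a 2.3-fold higher number from compound 2 to compound 4 (0.36 log units; beyond the scatter)). Approached from the other side, methoxy in place of hydrogen on the same ring also raises the number (a 2.8-fold higher number from compound 1 to compound 4 (0.45 log units; beyond the scatter)), so among compounds 1, 2 and 4 the number does not follow the count of methoxy groups: compound 1 and compound 2, with the fewest and the most of them, lie within the scatter of each other, while compound 4, with the middle count, has the highest number of the three. No measured evidence on hand explains this rise.

It remains open whether the same pattern on this ring holds with the 3,4-dimethoxyphenyl group of compound 3 on the carbonyl in place of the 4-aminophenyl group, as the compounds shown carry that group with only one methoxy pattern. Also open, on these data alone, is whether a hydroxyl group, a fluorine atom or an ethoxy group on this aromatic carbon would give a number closer to compound 2 or to compound 4.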